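Carbonyl substituent change from compound 2 to compound 3

The source may report more compounds than this note shows. Statements on the series, on what has been measured and on what is new or still open speak of the compounds shown alone.

Going by the values given here, in an ADME assay on MT4 cells (Homo sapiens) for cytotoxicity, read by MTT assay (a higher number here means that more compound is tolerated, a lower number that less compound is tolerated), compound 1 (`O=C1c2ccccc2C(=O)N1CCOC(=S)N(C(=O)c1cc(Cl)cc(Cl)c1)c1ccc(Cl)cc1`) gives 32000 nM and compound 2 (`O=C1c2ccccc2C(=O)N1CCOC(=S)N(C(=O)c1cc([N+](=O)[O-])ccc1Cl)c1ccc(Cl)cc1`) gives 45000 nM, so compound 2 stands within the scatter of its only measured neighbour. Compound 3 (`Cc1cc(C(=O)N(C(=S)OCCN2C(=O)c3ccccc3C2=O)c2ccc(Cl)cc2)ccc1Br`) carries 4-bromo-3-methylphenyl in place of 2-chloro-5-nitrophenyl on a carbonyl carbon. Among the compounds with values here, the one measured change at this place, a 1.4-fold higher number from compound 1 to compound 2 (0.15 log units; within the scatter), stayed within the scatter, and it is the only guide. No step beyond the scatter is therefore expected in this assay. The estimated step is a 1.3-fold lower number from compound 2 to compound 3 (0.11 log units; within the scatter). For compound 3 the expected value is 35000 nM, with an estimated range of 14000 nM to 85000 nM.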

Compound 3, half-maximal cytotoxic concentration: 18000 nM
Estimate against measurement, compound 3: 1.9-fold (0.29 log units) above, within the range that was stated.
By their numbers in this assay, from the lowest: compounds 3, 1 and 2 (each within the scatter of the next, the first and the last beyond it).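

In this assay, this position now shows a step beyond the scatter, a 2.5-fold lower number from compound 2 to compound 3 (0.40 log units; beyond the scatter), with 4-bromo-3-methylphenyl replacing 2-chloro-5-nitrophenyl on the carbonyl carbon. The same entering group gives a 1.8-fold lower number from compound 1 to compound 3 (0.25 log units; within the scatter), so the size of the step depends on which group leaves. No measured evidence here accounts for the difference between these steps. On these data alone, it remains open whether the larger step belongs to the leaving or the entering group. As far as these compounds go, how a phenyl bearing an amine or a carboxylic acid would read at this carbonyl carbon also remains open.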